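Swapping bromo for hydroxy on compound 3

The source may hold more compounds than are shown below. What is called first, only, known or untested is meant among the compounds shown, and "the series" means these compounds.

Compound 1 `COc1cccc(/C=C2\CCC/C(=C\c3cccc(Cl)c3)C2=O)c1OC` gives 21400 nM
Compound 2 `COc1cccc(/C=C2\CCC/C(=C\c3cccc(Br)c3)C2=O)c1OC` gives 23900 nM
Compound 3 `COc1cccc(/C=C2\CCC/C(=C\c3ccc(Br)cc3)C2=O)c1OC` gives 21400 nM

These three values come from an ADME assay on NHDF cells (Homo sapiens) for cytotoxicity, read by MTT assay, with a stated time of 72 h (on this read-out higher numbers stand for weaker inhibition and lower numbers for stronger inhibition), and lie within the usual scatter of one another. Compound 3 shares its figure with compound 1 and is within the scatter of compound 2.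

The next compound is compound 4 `COc1cccc(/C=C2\CCC/C(=C\c3ccc(O)cc3)C2=O)c1OC`, which has hydroxy in place of bromo on an aromatic carbon. Three measured steps offer some guidance. Bromo in place of chloro gave a 1.1-fold higher number from compound 1 to compound 2 (0.05 log units; within the scatter). 4-Bromophenyl in place of 3-bromophenyl gave a 1.1-fold lower number from compound 2 to compound 3 (0.05 log units; within the scatter), and 4-bromophenyl in place of 3-chlorophenyl gave no change at the digits printed from compound 1 to compound 3 (within the scatter). All of these stay within the scatter, but none brings in a hydroxy, so they guide the expectation only loosely. No step beyond the scatter is expected, and no direction is firmly expected, though the uncertainty is wide.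

The expected change is a 1.1-fold lower number from compound 3 to compound 4 (0.05 log units; within the scatter). For compound 4 the estimated value is 19000 nM, with an expected range from 8000 nM to 42000 nM.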

Compound 4, half-maximal inhibitory concentration: > 50000 nM
Compound 4 gave a limit, no number; the forecaster's own chance of this, stated with the estimate: 8%; middle value at least 2.6-fold (0.42 log units) from the limit.
By their numbers in this assay, from the lowest: compounds 1, 3 and 2 (each within the scatter of the next). At a limit, above all of these: compound 4.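

Compounds 1, 2 and 3, with chloro or bromo on this ring, stayed within the scatter of one another in this assay, so they gave no sign that this ring was sensitive to change. Hydroxy in place of bromo, on an aromatic carbon para to a large group, is the first change to go beyond the scatter, pointing to weaker inhibition, with an at least 2.3-fold higher number from compound 3 to compound 4 (0.36 log units; beyond the scatter), alongside an at least 2.0-fold higher number from compound 2 to compound 4 (0.32 log units; beyond the scatter) and an at least 2.3-fold higher number from compound 1 to compound 4 (0.36 log units; beyond the scatter). Compound 4 is known only by a limit, so these steps give only a minimum size: the limit of > 50000 nM in this assay, at which 1 of the 4 values shown sits.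

From the compounds shown here alone, it remains open whether an amine or a carboxylic acid at the same place would behave like hydroxy or like bromo. Also open, going by these compounds, is whether hydroxy would have the same effect at the ring position that carries chloro in compound 1.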